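The source may report more compounds than this note shows. Statements on the series, on what has been measured and on what is new or still open speak of the compounds shown alone.

Measured compounds:
- compound 1 `C#CCNC1CCc2c(SCCc3ccc(Br)cc3)cccc21`: 85300 nM
- compound 2 `C#CCNC1CCc2c(SCCc3cccc(C)c3)cccc21`: 0.35 nM
- compound 3 `C#CCNC1CCc2c(SCCc3ccc(C)cc3)cccc21`: 25800 nM

All three were tested in an assay on isolated protein for inhibition of Amine oxidase [flavin-containing] B (Homo sapiens); on this read-out lower numbers stand for stronger inhibition and higher numbers for weaker inhibition. Among the three numbers, compound 2 stands lowest: its nearest neighbour is compound 3, reached by a 74000-fold higher number from compound 2 to compound 3 (4.87 log units; beyond the scatter), and compound 1 lies further away, as a 240000-fold lower number from compound 1 to compound 2 (5.39 log units; beyond the scatter) shows. Compound 4 `C#CCNC1CCc2c(SCCc3cccc(C(F)(F)F)c3)cccc21` is the next step from compound 2: trifluoromethyl in place of methyl on an aromatic carbon, on an aromatic carbon of a six-membered aromatic ring of carbon only, meta to a large group.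

Which measured steps bear on this? The two large steps, from compound 1 to compound 2 and from compound 2 to compound 3, each move a group from one aromatic carbon to another and say little about swapping one group for another at the same carbon. For the measured compounds named here, the only step of that kind is a 3.3-fold lower number from compound 1 to compound 3 (0.52 log units; beyond the scatter), a modest one. Because of a 3.3-fold lower number from compound 1 to compound 3 (0.52 log units; beyond the scatter), a modest step is expected here too, and its direction cannot be read from the data, so compound 4 is estimated at 1.5 nM (range 0.2 nM to 15 nM). That estimate means the step of a 4.3-fold higher number from compound 2 to compound 4 (0.63 log units; beyond the scatter) from compound 2 to compound 4 is expected.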

Compound 4, half-maximal inhibitory concentration: 3720 nM
Estimate against measurement, compound 4: 2500-fold (3.39 log units) below; measured number outside the range, above it.
By their numbers in this assay, from the lowest: compound 2; then compound 4; then compound 3; then compound 1.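

In this assay, exchanging one group for another on this aromatic carbon turns out to be a large change: an 11000-fold higher number from compound 2 to compound 4 (4.03 log units; beyond the scatter). For the compounds shown here, the only earlier exchange of this kind was modest, a 3.3-fold lower number from compound 1 to compound 3 (0.52 log units; beyond the scatter), so that step gave no warning of how much could be lost. The earlier large steps, such as a 74000-fold higher number from compound 2 to compound 3 (4.87 log units; beyond the scatter), came from moving a group to another ring carbon, whereas here the place stays the same and only methyl gives way to trifluoromethyl, so the identity of the group matters as well as its place.

Going by these compounds, whether a chlorine, a methoxy group or an amine on this same carbon would stay close to compound 2 or fall away like compound 4 remains open. No measurement among those given accounts for the size of this step.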